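Substituent at the aryl carbon of a fused bicyclic series

The source may hold more compounds than are shown below. What is called first, only, known or untested is meant among the compounds shown, and "the series" means these compounds.

Measured so far:
compound 1, `Cc1n[nH]cc1-c1cccc2c1CCC2c1ncc[nH]1`: 3 nM
compound 2, `c1ccc2c(c1)CCC2c1ncc[nH]1`: 473 nM

In a functional assay on CHO cells for agonist activity at Alpha-1A adrenergic receptor (Homo sapiens), read by FLIPR and calcium flux (a higher number here means that more compound is needed for the effect, a lower number that less compound is needed), compound 2 gives 473 nM, the highest of the two numbers; its nearest neighbour is compound 1, which gives 3 nM. Compound 3, `CCS(=O)(=O)Nc1cccc2c1CCC2c1ncc[nH]1`, has not yet been measured. The change from compound 2 to compound 3 is (ethylsulfonyl)amino in place of hydrogen on an aromatic carbon. Among the measured compounds shown here, the one measured step that bears on it is a 160-fold higher number from compound 1 to compound 2 (2.20 log units; beyond the scatter), in which the same aromatic carbon went from substituted to bare with a large rise in this assay. Compound 3 refills that carbon, though with a group unlike the pyrazolyl of compound 1, so a drop is expected, likely smaller than the measured step because a 160-fold higher number from compound 1 to compound 2 (2.20 log units; beyond the scatter) involved a different group. Compound 3 is therefore expected to give about 40 nM, between 8 nM and 250 nM, an estimated step of a 12-fold lower number from compound 2 to compound 3 (1.07 log units; beyond the scatter).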

Compound 3, half-maximal effective concentration: 32 nM
Beside the measured number, compound 3's estimate is 1.3-fold (0.10 log units) above it; measured number inside the range.
By their numbers in this assay, from the lowest: compound 1; then compound 3; then compound 2.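

In this assay the move from a bare carbon to (ethylsulfonyl)amino gives a 15-fold lower number from compound 2 to compound 3 (1.17 log units; beyond the scatter), so a lower number at this aromatic carbon is not confined to the 3-methyl-1H-pyrazol-4-yl group and also occurs with a substituent that has no ring. The two substituents are not interchangeable, however: exchanging one for the other gives an 11-fold higher number from compound 1 to compound 3 (1.03 log units; beyond the scatter), so the identity of the group matters here as well as the presence of a substituent. Nothing available explains either step.

Still open, as far as these compounds go, is whether the sulfonyl or the nitrogen of the (ethylsulfonyl)amino group accounts for the step, a question that a plain amine or an acetamide on this carbon would address. Also open, from the compounds shown here alone, is how a longer chain on the sulfonyl, or a pyrazole without its methyl, would compare with compound 3 and compound 1.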